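3-methoxybenzyl to 2-methoxybenzyl: compound 3 to compound 4

This account rests on a few compounds, and the source may have more. Where it says the series, first, only, none or still open, it means among the compounds named here.

In an ADME assay on L02 cells (Homo sapiens) for inhibition, read by CCK-8 assay, with a stated time of 48 h (on this read-out lower numbers stand for stronger inhibition of growth and higher numbers for weaker inhibition of growth), compound 1 `CN1CCN(c2ccc(Nc3ncc(Cl)c(NCc4ccc(F)cc4)n3)nc2)CC1` gives 39700 nM, compound 2 `COc1ccc(CNc2nc(Nc3ccc(N4CCN(C)CC4)cn3)ncc2Cl)cc1` gives 12900 nM and compound 3 `COc1cccc(CNc2nc(Nc3ccc(N4CCN(C)CC4)cn3)ncc2Cl)c1` gives 16200 nM. The number for compound 3 lies within the scatter of that for compound 2 and clearly under that for compound 1, as a 2.5-fold lower number from compound 1 to compound 3 (0.39 log units; beyond the scatter) shows. Compound 4 `COc1ccccc1CNc1nc(Nc2ccc(N3CCN(C)CC3)cn2)ncc1Cl` differs from compound 3 by 2-methoxyphenyl in place of 3-methoxyphenyl on a saturated chain carbon bound to a nitrogen on an aromatic ring. Going by the values given here, the nearest precedent is a methoxy relocation, a 1.3-fold higher number from compound 2 to compound 3 (0.10 log units; within the scatter). The replacement of fluoro by methoxy, a 3.1-fold lower number from compound 1 to compound 2 (0.49 log units; beyond the scatter), is a different change and bears less directly. Among the compounds with values here, no 2-methoxyphenyl compound has been measured, so no step beyond the scatter is expected in this assay. The expected step is a 1.1-fold lower number from compound 3 to compound 4 (0.03 log units; within the scatter). For compound 4 the estimate is 15000 nM, with an expected range of 7500 nM to 30000 nM.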

Compound 4, concentration for 50% growth inhibition: 25500 nM
Estimate against measurement, compound 4: 1.7-fold (0.23 log units) below, within the range that was stated.
By their numbers in this assay, from the lowest: compounds 2, 3, 4 and 1 (each within the scatter of the next, the first and the last beyond it).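

In this assay, the 2-methoxyphenyl group gives a 1.6-fold higher number from compound 3 to compound 4 (0.20 log units; within the scatter) and a 2.0-fold higher number from compound 2 to compound 4 (0.30 log units; within the scatter), so the three methoxyphenyl isomers at this place lie within the scatter of one another. The separation from the 4-fluorophenyl compound seen for compound 2 and compound 3 is not seen for this isomer, with a 1.6-fold lower number from compound 1 to compound 4 (0.19 log units; within the scatter). Nothing available accounts for these numbers.

Open, as far as these compounds go, is whether a hydroxyphenyl, ethoxyphenyl or dimethylaminophenyl group at this place would stand beyond the scatter of the methoxyphenyl compounds.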